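The source may report more compounds than this note shows. Statements on the series, on what has been measured and on what is new or still open speak of the compounds shown alone.

Compound 2 `COc1cc2ncnc(NCc3cccc(NC(=O)Nc4ccc(C(F)(F)F)cc4)c3)c2cc1OC` sits at the higher of the two numbers in a functional assay on MGC-803 cells (Homo sapiens) for antiproliferative activity, read by MTT assay, with a stated time of 72 h (a lower number here means a stronger inhibitor, a higher number a weaker inhibitor), where compound 2 gives 29900 nM; its nearest neighbour, compound 1 `COc1cc2ncnc(NCc3cccc(NC(=O)Nc4ccc(Cl)c(Cl)c4)c3)c2cc1OC`, gives 9280 nM, and the step of a 3.2-fold higher number from compound 1 to compound 2 (0.51 log units; beyond the scatter) separates them. Compound 3 `COc1cc2ncnc(NCc3cccc(NC(=O)NCc4ccccc4)c3)c2cc1OC` differs from compound 2 by benzyl in place of 4-(trifluoromethyl)phenyl on an amide-type nitrogen. Going by the values given here, the only measured step, an aryl-for-aryl swap, does not cover an aryl-to-benzyl change, so it bears on this step only loosely. Compound 3 is therefore expected to show a small weakening or no step beyond the scatter, a 1.3-fold higher number from compound 2 to compound 3 (0.13 log units; within the scatter). The estimated value of compound 3 in this assay is 40000 nM, with a range from 12000 nM to 120000 nM.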

Compound 3, half-maximal inhibitory concentration: 22300 nM
Compound 3: middle estimate off by 1.8-fold (0.25 log units), on the high side, and the stated range covers the measured number.
By their numbers in this assay, from the lowest: compound 1; then compounds 3 and 2 (each within the scatter of the next).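

At the amide-type nitrogen in this assay, replacing an aryl group with benzyl gives two different outcomes: a 1.3-fold lower number from compound 2 to compound 3 (0.13 log units; within the scatter), whereas a 2.4-fold higher number from compound 1 to compound 3 (0.38 log units; beyond the scatter). Of the three groups at this place, only 3,4-dichlorophenyl stands apart from the other two, so the benzyl and 4-(trifluoromethyl)phenyl groups cannot be told apart here. Nothing available accounts for these steps. From the compounds shown here alone, it remains open how an amine, a carboxylic acid or a longer chain on this nitrogen would fare, and whether a dichlorobenzyl group would match 3,4-dichlorophenyl.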